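A few compounds are considered here, and "the series" means these few. Any claim that something is new, unique, unknown or untested is made for them only; others in the source may bear on it.

Compound 1 `O=C1OCCN1C(=O)c1ccc(Oc2ccccc2)cc1` gives 680 nM in an assay on HEK293 cells for inhibition of N-acylethanolamine-hydrolyzing acid amidase (Rattus norvegicus), read by LC-MS, with a stated time of 30 min; on this read-out higher numbers stand for weaker inhibition and lower numbers for stronger inhibition. Compound 2 `O=C1OCCN1C(=O)c1ccc(Oc2cccc(Cl)c2)cc1` gives 7740 nM. Compound 3 `O=C1OCCN1C(=O)c1ccc(OC2CCCC2)cc1` gives 120 nM.

Compound 3 stands lowest of the three, separated from the others by a 5.7-fold lower number from compound 1 to compound 3 (0.75 log units; beyond the scatter) and by a 65-fold lower number from compound 2 to compound 3 (1.81 log units; beyond the scatter). Compound 4 `CCC(CC)Oc1ccc(C(=O)N2CCOC2=O)cc1` differs from it by pentan-3-yl in place of cyclopentyl on an oxygen on an aromatic ring. Going by the values given here, the only measured step at that oxygen, a 5.7-fold lower number from compound 1 to compound 3 (0.75 log units; beyond the scatter), swapped an aromatic ring for a saturated one; the step of an 11-fold higher number from compound 1 to compound 2 (1.06 log units; beyond the scatter) concerns a different place and does not bear on this change. Among the compounds with values here, no measured pair shows a ring opened to a branched chain, so the expectation rests on compound 3 alone. Compound 4 is therefore estimated at 200 nM, within 60 nM to 700 nM. This estimate implies an expected step of a 1.7-fold higher number from compound 3 to compound 4 (0.22 log units; within the scatter), within the scatter.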

Compound 4, half-maximal inhibitory concentration: 480 nM
Estimate against measurement, compound 4: 2.4-fold (0.38 log units) below; measured number inside the range.
By their numbers in this assay, from the lowest: compound 3; then compounds 4 and 1 (each within the scatter of the next); then compound 2.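

With the same five carbons on the oxygen, the open pentan-3-yl does not match the cyclopentyl ring in this assay (a 4.0-fold higher number from compound 3 to compound 4 (0.60 log units; beyond the scatter)), so the carbon count alone does not carry the result of compound 3. A saturated group at this oxygen therefore does not by itself give a gain over phenyl (a 1.4-fold lower number from compound 1 to compound 4 (0.15 log units; within the scatter)), although pentan-3-yl remains far from 3-chlorophenyl (a 16-fold lower number from compound 2 to compound 4 (1.21 log units; beyond the scatter)). No evidence is available that bears on this difference. Still open, going by these compounds, is how cyclobutyl or cyclohexyl would compare with cyclopentyl at this oxygen. A straight pentyl chain also remains to be compared with pentan-3-yl.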